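The source may hold more compounds than are shown below. What is called first, only, known or untested is meant among the compounds shown, and "the series" means these compounds.

Of the compounds shown here, three sharing one core have been measured in a functional assay on the whole organism for inhibition, with Rattus norvegicus as the target, read by paw edema, with stated times of 30 min and 4 h, at a dose of 0.28 mmol/kg by the oral route; on this read-out higher numbers stand for more inhibition at the one dose given (going by the name of the read-out) and lower numbers for less inhibition. Compound 1 `CCNC(=O)c1nc(-c2cc(OC)c(OC)c(OC)c2)n(-c2ccc(OC)cc2)n1` carries an ethyl group on the amide nitrogen and gives 58%. Compound 2 `COc1ccc(-n2nc(C(=O)Nc3ccccc3OC)nc2-c2cc(OC)c(OC)c(OC)c2)cc1`, which has a 2-methoxyphenyl in place of ethyl on that nitrogen, gives 24%, and compound 3 `COc1ccc(-n2nc(C(=O)Nc3ccccc3C)nc2-c2cc(OC)c(OC)c(OC)c2)cc1`, with a 2-methylphenyl there, gives 46%. Among these three numbers compound 2 stands lowest: the nearest is compound 3 and the furthest is compound 1, and both gaps lie beyond the scatter. The measured steps read a number 34 percentage points lower from compound 1 to compound 2 (beyond the scatter), a number 12 percentage points lower from compound 1 to compound 3 (beyond the scatter) and a number 22 percentage points higher from compound 2 to compound 3 (beyond the scatter).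

Compound 4 `COc1ccc(-n2nc(C(=O)Nc3ccccc3)nc2-c2cc(OC)c(OC)c(OC)c2)cc1` has not yet been measured in this assay. It differs from compound 2 in one place: hydrogen in place of methoxy on an aromatic carbon. The step that bears most closely on this change is a number 22 percentage points higher from compound 2 to compound 3 (beyond the scatter), since it also took the methoxy off that aromatic carbon, although a methyl entered there rather than a hydrogen. Going by the values given here, the step of a number 34 percentage points lower from compound 1 to compound 2 (beyond the scatter) shows that the 2-methoxyphenyl group is the one that brought the number down the most. A modest rise is therefore expected, and the estimated step is a number 16 percentage points higher from compound 2 to compound 4 (beyond the scatter). On these grounds compound 4 is expected to give about 40% in this assay, within a range of 25% to 56%.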

Compound 4, a percentage reported as inhibition, in the whole organism at one dose (the size of the read-out at that dose, not a potency): 50%
Beside the measured number, compound 4's estimate is 10 percentage points below it; measured number inside the range.
By their numbers in this assay, from the lowest: compound 2; then compounds 3, 4 and 1 (each within the scatter of the next, the first and the last beyond it).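

In this assay, the change gives a number 26 percentage points higher from compound 2 to compound 4 (beyond the scatter), so the low number of compound 2 goes with the methoxy on this ring and not with a phenyl on the amide nitrogen as such. With a number 4 percentage points higher from compound 3 to compound 4 (within the scatter), a hydrogen and a methyl at this place cannot be told apart, and with a number 8 percentage points lower from compound 1 to compound 4 (within the scatter), the plain phenyl cannot be told apart from the ethyl on the amide nitrogen, so among the groups shown only the methoxy marks a clear loss at this position. No measurement at hand explains why the methoxy goes with the lower number.

The compounds shown compare only hydrogen, methyl and methoxy at this place, so it remains open whether a larger ether such as ethoxy, a halogen such as chlorine, or an amine would follow the methoxy or stay with hydrogen and methyl. On these data alone, it also remains open whether a longer chain than ethyl on the amide nitrogen would hold the number seen for compound 1.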